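The source may report more compounds than this note shows. Statements on the series, on what has been measured and on what is new or still open speak of the compounds shown alone.

Measured compounds:
- Compound 1, `Cc1cc(C)c(S(=O)(=O)N2CCC(N3CCN(C)CC3)CC2)c(C)c1`: 1100 nM
- Compound 2, `Cc1cc(C)c(S(=O)(=O)N2CCC(N3CCCCCC3)CC2)c(C)c1`: 5.3 nM
- Compound 3, `Cc1cc(C)c(S(=O)(=O)N2CCC(N3CCC(Cc4ccccc4F)CC3)CC2)c(C)c1`: 74 nM

In a functional assay on DLD-1 cells (Homo sapiens) for antiproliferative activity, read by CellTiter-Glo, with a stated time of 72 h (on this read-out higher numbers stand for weaker inhibition and lower numbers for stronger inhibition), compound 3 gives 74 nM, the second highest of the three numbers. Its nearest neighbour is compound 2 with 5.3 nM, a lower number beyond the scatter, and its furthest is compound 1 with 1100 nM, a higher number beyond the scatter. Among the compounds with values here, the only step between compounds that differ in a single place is a 210-fold lower number from compound 1 to compound 2 (2.32 log units; beyond the scatter), a large drop in the number.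

Compound 4, `Cc1cc(C)c(S(=O)(=O)N2CCC(N3CCCCC3)CC2)c(C)c1`, has not yet been measured in this assay. It differs from compound 3 in one place: hydrogen in place of 2-fluorobenzyl on a saturated ring carbon. Within the data shown here, no measured pair shows this change itself, so the step from compound 1 to compound 2 bears on it only loosely, as an example of how strongly the group on that saturated ring carbon can move the number. Since compound 2 gives 5.3 nM with a group of similar size and no substituent, compound 4 is expected to sit between the numbers of compound 3 and compound 2, and the step is estimated as a 4.9-fold lower number from compound 3 to compound 4 (0.69 log units; beyond the scatter). Compound 4 is therefore estimated at 15 nM, within a range of 4 nM to 60 nM.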

Compound 4, half-maximal inhibitory concentration: 2200 nM
The estimate for compound 4 lay 150-fold (2.17 log units) below the measured number; measured number outside the range, above it.
By their numbers in this assay, from the lowest: compound 2; then compound 3; then compounds 1 and 4 (each within the scatter of the next).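

In this assay, taking 2-fluorobenzyl off the saturated ring carbon gives a 30-fold higher number from compound 3 to compound 4 (1.47 log units; beyond the scatter), so on the piperidin-1-yl group of this series the substituent at that carbon, three ring bonds from the ring nitrogen, accounts for a large part of the lower number of compound 3, and the bare ring does not carry it. Ring size matters just as sharply, as azepan-1-yl and piperidin-1-yl, two unsubstituted rings, are separated by a 420-fold higher number from compound 2 to compound 4 (2.62 log units; beyond the scatter), which shows that the low number of compound 2 does not extend to every plain saturated ring amine on the core. Piperidin-1-yl and 4-methylpiperazin-1-yl, by contrast, are not told apart, with a 2.0-fold higher number from compound 1 to compound 4 (0.30 log units; within the scatter), and no measurement shown here explains any of these steps.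

The compounds shown leave open whether the fluorine or the benzyl group is what matters on this carbon, which a plain benzyl, a methyl or a hydroxyl at the same place would begin to separate. They also leave open how a pyrrolidin-1-yl ring would compare, and whether a 2-fluorobenzyl on the azepan-1-yl ring of compound 2 would lower or raise its number.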